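This account rests on a few compounds, and the source may have more. Where it says the series, first, only, none or still open, it means among the compounds named here.

Compound 1, with the structure `COc1cc(/C=C/C(=O)/C=C/c2ccco2)ccc1OCc1cn(CCCOc2cc(=O)oc3ccccc23)nn1`, and compound 2, with the structure `COc1ccccc1/C=C/C(=O)/C=C/c1ccc(OCc2cn(CCCOc3cc(=O)oc4ccccc34)nn2)c(OC)c1`, share one core and differ in a single place: 2-methoxyphenyl in place of furan-2-yl on a double-bonded chain carbon bound to a double-bonded chain carbon. In a functional assay on COLO 205 cells (Homo sapiens) for inhibition, read by sulforhodamine B assay, with a stated time of 48 h, tested at 50 uM (a higher number here means more inhibition of growth at the concentration tested, a lower number less inhibition of growth), compound 1 gives 59%, while compound 2 gives 57%, so that the change made a number 2 percentage points lower from compound 1 to compound 2 (within the scatter). Compound 3, with the structure `COc1cc(/C=C/C(=O)/C=C/c2ccco2)ccc1OCc1cn(CCOc2cc(=O)oc3ccccc23)nn1`, carries a core that is built differently; how its core differs from that of compound 1 is not broken down here. In this assay compound 3 gives 68%, the highest of the three numbers, though only the gap to compound 2 lies beyond the usual scatter.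

Compound 4, with the structure `COc1ccccc1/C=C/C(=O)/C=C/c1ccc(OCc2cn(CCOc3cc(=O)oc4ccccc34)nn2)c(OC)c1`, has not yet been measured. It differs from compound 3 by 2-methoxyphenyl in place of furan-2-yl on a double-bonded chain carbon bound to a double-bonded chain carbon, the same kind of change that separates compound 1 from compound 2, at the same place. Because that change gave a number 2 percentage points lower from compound 1 to compound 2 (within the scatter), a step of similar size is expected here, a number 3 percentage points lower from compound 3 to compound 4 (within the scatter). Compound 4 is therefore estimated to give 65% in this assay, with an expected range from 52% to 76%.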

Compound 4, percent growth inhibition at one concentration: 67%
Compound 4: the middle estimate sits 2 percentage points below what was measured; the measured number falls inside the stated range.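

On the second core, 2-methoxyphenyl in place of furan-2-yl gave a number 1 percentage points lower from compound 3 to compound 4 (within the scatter) in this assay. The change thus behaved the same way on both cores, with neither step large enough to stand out from ordinary repeat-to-repeat variation: the same change on two cores in this assay, a number 2 percentage points lower (within the scatter) from compound 1 to compound 2 and a number 1 percentage points lower (within the scatter) from compound 3 to compound 4, 1 percentage points apart, within the scatter of two such steps This shows that, on these two cores, the larger 2-methoxyphenyl ring can stand where furan-2-yl stands without a detectable shift in growth inhibition, but it does not show that the same would hold on any other core, nor does it explain why the number stays put.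

The compounds shown carry only these two aromatic rings at this place, so it remains open whether a quite different group there, such as an amine or a carboxylic acid, would move the number beyond the scatter. Each number also comes from a single tested concentration, which leaves open how these compounds would compare at other concentrations.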